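Notes on the step from compound 3 to compound 4

A few compounds are considered here, and "the series" means these few. Any claim that something is new, unique, unknown or untested is made for them only; others in the source may bear on it.

Measured in an ADME assay on microsomes from liver (Homo sapiens) for metabolic stability, with a stated time of 10 min (on this read-out higher numbers stand for a more stable compound and lower numbers for a less stable compound), so far
compound 1 `CC[C@]1(C(=O)O)CC[C@H](C(=O)N2CC[C@](c3ccc(C(F)(C(F)(F)F)C(F)(F)F)cc3)(S(=O)(=O)c3ccc(F)cc3)C2)CC1` gives 100%
compound 2 `O=C(O)[C@H]1CC[C@](F)(C(=O)N2CC[C@](c3ccc(C(F)(C(F)(F)F)C(F)(F)F)cc3)(S(=O)(=O)c3ccc(F)cc3)C2)CC1` gives "not determined" (no result reported)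
compound 3 `O=C(O)C12CCC(C(=O)N3CC[C@](c4ccc(C(F)(C(F)(F)F)C(F)(F)F)cc4)(S(=O)(=O)c4ccc(F)cc4)C3)(CC1)OC2` gives 90%

Going by the values given here, compound 3 stands level with compound 1 within the scatter, and these are the only two numbers so far. In compound 4 `O=C([C@H]1CC[C@H](CO)CC1)N1CC[C@](c2ccc(C(F)(C(F)(F)F)C(F)(F)F)cc2)(S(=O)(=O)c2ccc(F)cc2)C1` the change is a group of 8 heavy atoms (7 carbon, 1 oxygen; one six-membered non-aromatic ring of carbon only) in place of a group of 11 heavy atoms (8 carbon, 3 oxygen; one six-membered non-aromatic ring of carbon only, one six-membered non-aromatic ring with 1 hetero atom), on a carbonyl carbon, with 4-(hydroxymethyl)cyclohexyl as the entering group. Among the compounds with values here, the one measured step, a number 10 percentage points lower from compound 1 to compound 3 (within the scatter), also exchanged the group on a carbonyl carbon but kept its heavy-atom count, so it bears only loosely on this change. Within the data shown here, with compound 3 at 90% little room remains upward, so a modest fall in this assay is expected, although no measured step covers it. The estimated step is a number 15 percentage points lower from compound 3 to compound 4 (beyond the scatter). For compound 4 the expected value is 75%, with an estimated range of 50% to 95%.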

Compound 4, percent of the compound remaining: 75%
Beside the measured number, compound 4's estimate shows no gap at the digits printed; low and high end bracket the measured number.
By their numbers in this assay, from the lowest: compound 4; then compounds 3 and 1 (each within the scatter of the next).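

On the carbonyl carbon, 4-(hydroxymethyl)cyclohexyl gives a number 15 percentage points lower from compound 3 to compound 4 (beyond the scatter) and a number 25 percentage points lower from compound 1 to compound 4 (beyond the scatter) in this assay, so this position can move the read-out, which the earlier step, a number 10 percentage points lower from compound 1 to compound 3 (within the scatter), did not show. Compounds 1 and 3 carry a carboxylic acid on the group at this position and compound 4 does not, but the groups also differ elsewhere. Nothing at hand explains the fall. The compounds shown leave open whether the change follows the loss of the carboxylic acid or the presence of hydroxymethyl. An aminomethyl or methoxymethyl group on the same cyclohexyl would separate these readings.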